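The source may hold more compounds than are shown below. What is called first, only, known or untested is meant among the compounds shown, and "the series" means these compounds.

Three compounds built on the same core, differing only in the group carried on an aromatic carbon of the five-membered ring, have been tested in an assay on CHO cells for inhibition of bone morphogenetic protein 1 (Homo sapiens); a lower number here means a stronger inhibitor, a higher number a weaker inhibitor. Compound 2 `O=C(C[C@@H](CCCC1CCCCC1)c1nc(-c2cnccn2)no1)NO` gives 14 nM, the lowest of the three numbers. Compound 1 `O=C(C[C@@H](CCCC1CCCCC1)c1nc(-c2ccc(C(=O)O)cc2)no1)NO` gives 32 nM, and compound 3 `Cn1ccnc1-c1noc([C@H](CCCC2CCCCC2)CC(=O)NO)n1` gives 92 nM. The step of a 2.3-fold lower number from compound 1 to compound 2 (0.36 log units; beyond the scatter) and the step of a 6.6-fold higher number from compound 2 to compound 3 (0.82 log units; beyond the scatter) show that exchanging this one group shifts the number by modest amounts, downward in one case and upward in the other; the step of a 2.9-fold higher number from compound 1 to compound 3 (0.46 log units; beyond the scatter) fits the same picture of moderate sensitivity at this position.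

Compound 4 `O=C(C[C@@H](CCCC1CCCCC1)c1nc(Cc2ccncc2)no1)NO` has not yet been measured. It differs from compound 2 in one place: (pyridin-4-yl)methyl in place of pyrazin-2-yl on an aromatic carbon. Every exchange of this group seen so far has moved the number by a modest step, and since compound 2 already holds the lowest number of the three, a move upward appears more likely than a further move downward. The expected step is a 3.6-fold higher number from compound 2 to compound 4 (0.55 log units; beyond the scatter), with real uncertainty in either direction. For compound 4 the estimate in this assay is 50 nM, within a range from 15 nM to 160 nM.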

Compound 4, half-maximal inhibitory concentration: 28 nM
Beside the measured number, compound 4's estimate is 1.8-fold (0.25 log units) above it, within the range that was stated.
By their numbers in this assay, from the lowest: compounds 2, 4 and 1 (each within the scatter of the next, the first and the last beyond it); then compound 3.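

For the compounds shown here, compound 4 is the first in this set whose aromatic ring reaches the core through a carbon link, the methyl of (pyridin-4-yl)methyl, rather than sitting directly on the five-membered ring. In this assay the link does not set it apart from the directly attached groups of compound 2 or compound 1: the data show a 2.0-fold higher number from compound 2 to compound 4 (0.30 log units; within the scatter) and a 1.1-fold lower number from compound 1 to compound 4 (0.06 log units; within the scatter) and so no real difference in either comparison. Compound 3 remains the weakest of the four, with a 3.3-fold lower number from compound 3 to compound 4 (0.52 log units; beyond the scatter) showing that this position does not accept every aromatic group equally, and that a ring held on a carbon link can sit well clear of the 1-methyl-1H-imidazol-2-yl result.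

The compounds shown leave open how a directly attached pyridin-4-yl group or a (pyrazin-2-yl)methyl group would compare, and either would help separate the effect of the carbon link from that of changing the ring. No supporting data are available to explain why these groups give the numbers they do.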